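The source may report more compounds than this note shows. Statements on the series, on what has been measured and on what is new or still open speak of the compounds shown alone.

In a functional assay on A549 cells (Homo sapiens) for cytotoxicity, read by MTT assay (a lower number here means a stronger inhibitor, a higher number a weaker inhibitor), compound 1 `COc1cc2ncnc(Nc3cc(-c4ccc(F)cc4)[nH]n3)c2cc1OC` gives < 100000 nM, which is a limit and not a number. Compound 2 `COc1cc2ncnc(Nc3cc(-c4ccc(Cl)cc4)[nH]n3)c2cc1OC` gives < 100000 nM, again a limit, so the limit of < 100000 nM in this assay, at which 2 of the 2 values shown sit, describes all the evidence so far. Replacing fluoro with chloro is a step that the two limits leave unreadable from compound 1 to compound 2. Compound 3 `COc1ccc(-c2cc(Nc3ncnc4cc(OC)c(OC)cc34)n[nH]2)cc1` carries methoxy in place of chloro on an aromatic carbon, with methoxy in place of chloro on an aromatic carbon. Within the data shown here, the one measured step, a step that the two limits leave unreadable from compound 1 to compound 2, gives no size to build on, so no firm size or direction can be expected in this assay. The estimated change is a step that the limit leaves unreadable from compound 2 to compound 3. For compound 3 the estimate is 30000 nM, with an expected range of 5000 nM to 100000 nM.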

Compound 3, half-maximal inhibitory concentration: < 100000 nM
Compound 3: only a limit was reported (the forecaster's own chance of this, stated with the estimate: 60%); the middle value does not contradict the limit.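

In this assay compound 3 gives only a limit, as compound 1 and compound 2 do, so no step among these three can be read. From the compounds shown here alone, whether fluoro, chloro and methoxy differ in their effect here, and by how much, stays open.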